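The compounds below may be only part of what the source reports. "The series", "measured", "known", "first", "only" and "open" are said of these compounds alone.

Compound 1 `Cc1ccc(CS/C(=C/c2c[nH]c3ccc(Br)cc23)C(=O)c2ccc(Cl)cc2)cc1` gives 1000 nM in a functional assay on DU-145 cells (Homo sapiens) for inhibition, read by trypan blue exclusion, with a stated time of 96 h; a lower number here means a stronger inhibitor of growth, a higher number a weaker inhibitor of growth. Compound 2 `O=C(/C(=C\c1c[nH]c2ccc(Br)cc12)SCc1ccc(Cl)cc1Cl)c1ccc(Cl)cc1` gives 10000 nM in this assay. Compound 3 `Cc1ccc(S/C(=C/c2c(O)cc(O)cc2O)C(=O)c2ccc(Cl)cc2)cc1` reaches only a limit of the assay, > 100000 nM in this assay.

Among the two numbers shown, compound 1 holds the lowest; the step of a 10-fold higher number from compound 1 to compound 2 (1.00 log units; beyond the scatter) separates it from its nearest neighbour, and compound 3 sits at the limit of > 100000 nM in this assay, at which 1 of the 3 values shown sits. The unmeasured compound 4 `Cc1ccc(CS/C(=C/c2cc([N+](=O)[O-])ccc2F)C(=O)c2ccc(Cl)cc2)cc1` differs from compound 1 in 2-fluoro-5-nitrophenyl in place of 5-bromo-1H-indol-3-yl on a double-bonded chain carbon bound to a double-bonded chain carbon. Among the compounds with values here, no measured step changes that part of the shared core, so the single step of a 10-fold higher number from compound 1 to compound 2 (1.00 log units; beyond the scatter) offers no direct guide, and compound 3, which differs from compound 1 in more than one place, only shows a limit. Compound 4 is therefore expected to be a somewhat weaker inhibitor, with the estimated step of a 4.0-fold higher number from compound 1 to compound 4 (0.60 log units; beyond the scatter), giving an estimated 4000 nM, expected between 800 nM and 30000 nM.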

Compound 4, concentration for 50% growth inhibition: 1000 nM
For compound 4 the middle estimate is 4.0-fold (0.60 log units) above the measured one, within the range that was stated.
By their numbers in this assay, from the lowest: compounds 1 and 4 (each within the scatter of the next); then compound 2. At a limit, above all of these: compound 3.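

Placing 2-fluoro-5-nitrophenyl where 5-bromo-1H-indol-3-yl stood gives no change at the digits printed from compound 1 to compound 4 (within the scatter) in this assay, the first reading of a change at this place on the double-bonded chain carbon. For this pair, the two-ring group with its hydrogen-bond donor is not needed to keep growth inhibition at this level, as a single-ring group with no donor serves as well. Nothing shown here explains why the two groups match.

The compounds shown leave open whether an unsubstituted phenyl or an aminophenyl at this place would read the same. As far as these compounds go, it also remains open whether 2-fluoro-5-nitrophenyl would behave alike alongside the 2,4-dichlorophenyl of compound 2.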